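Oxime ether chain variation on the shared core

This account rests on a few compounds, and the source may have more. Where it says the series, first, only, none or still open, it means among the compounds named here.

For the measured compounds named here, compound 1 `CCOC(=O)CO/N=C(\C)c1ccc(Sc2cc(F)cc(C3CCOCC3)c2)cc1` is measured in a functional assay (blood) for inhibition, with Homo sapiens as the target (a higher number here means a weaker inhibitor, a lower number a stronger inhibitor), at 610 nM, the highest of the three numbers so far. Compound 2 `O/N=C/c1ccc(Sc2cc(F)cc(C3CCOCC3)c2)cc1` gives 120 nM in this assay, and compound 3 `O/N=C(/c1ccc(Sc2cc(F)cc(C3CCOCC3)c2)cc1)C(F)(F)F` gives 280 nM. Both sit lower than compound 1: a 5.1-fold lower number from compound 1 to compound 2 (0.71 log units; beyond the scatter), and a 2.2-fold lower number from compound 1 to compound 3 (0.34 log units; beyond the scatter). Between the two smaller chains the gap is a 2.3-fold higher number from compound 2 to compound 3 (0.37 log units; beyond the scatter).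

Compound 4 `COC(=O)C(C)(C)CO/N=C(\C)c1ccc(Sc2cc(F)cc(C3CCOCC3)c2)cc1` has not been measured. Relative to compound 1 the change is 1-(methoxycarbonyl)-1-methylethyl in place of ethoxycarbonyl on a saturated chain carbon bound to an oxygen on an unsaturated carbon. Going by the values given here, no measured pair tests this change directly; the two known steps from compound 1 swap the whole chain for something shorter, whereas compound 4 keeps an ester-bearing oxime ether and adds to it. What the data show is only that the larger chain of compound 1 gave the highest number of the three, so a further extension is not expected to bring the number down. The expected outcome for compound 4 is therefore a number close to that of compound 1, with the step of a 1.2-fold higher number from compound 1 to compound 4 (0.09 log units; within the scatter) estimated to lie within the scatter or slightly beyond it toward a weaker inhibitor. Compound 4 is estimated at 750 nM, in the range 300 nM to 1900 nM.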

Compound 4, half-maximal inhibitory concentration: 420 nM
For compound 4 the middle estimate is 1.8-fold (0.25 log units) above the measured one; the range from low to high includes it.
By their numbers in this assay, from the lowest: compound 2; then compounds 3, 4 and 1 (each within the scatter of the next, the first and the last beyond it).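

Working notes on the oxime ether chain. In this assay, for the compounds shown here, the exchange of ethoxycarbonyl for 1-(methoxycarbonyl)-1-methylethyl on a saturated chain carbon bound to an oxygen on an unsaturated carbon gives a 1.5-fold lower number from compound 1 to compound 4 (0.16 log units; within the scatter) and is the first step that keeps an ester-bearing oxime ether instead of replacing the whole chain. With the ester kept, this larger, branched group leaves the number within the scatter, so a simple rule of a higher number for a larger chain does not hold for this pair, and compound 4 goes against any such reading. No measurement available here offers an explanation for this result.

From the compounds shown here alone, what remains open is whether a carboxylic acid or a primary amide in place of the ester would bring the number of this chain towards that of compound 2 at 120 nM and thereby show whether the ester itself matters here. Also open is how a longer chain or a terminal amine would read at this position, since the two ester chains shown cover only a narrow part of what could sit there.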